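This account rests on a few compounds, and the source may have more. Where it says the series, first, only, none or still open, it means among the compounds named here.

Compounds measured so far:
- compound 1, `OC[C@H]1O[C@@H](n2cnc3c(SCc4cccc(Cl)c4)ncnc32)[C@H](O)[C@@H]1O`: 18.2 nM
- compound 2, `OC[C@H]1O[C@@H](n2cnc3c(SCc4ccccc4Br)ncnc32)[C@H](O)[C@@H]1O`: 151 nM
- compound 3, `OC[C@H]1O[C@@H](n2cnc3c(SCc4ccccc4I)ncnc32)[C@H](O)[C@@H]1O`: 19.5 nM

In an assay on isolated protein for inhibition of Equilibrative nucleoside transporter 1 (Homo sapiens) (a higher number here means a weaker inhibitor, a lower number a stronger inhibitor), compound 1 gives 18.2 nM, the lowest of the three numbers. Compound 3 sits beside it, the two within the scatter of one another, while compound 2 stands apart with 151 nM, the step being an 8.3-fold higher number from compound 1 to compound 2 (0.92 log units; beyond the scatter). The move from a bromo to an iodo substituent on the aromatic carbon, a 7.7-fold lower number from compound 2 to compound 3 (0.89 log units; beyond the scatter), shows that the group carried on the phenyl ring matters at this place, even though the halogens themselves do not rank in a simple way.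

Compound 4, `N#Cc1ccccc1CSc1ncnc2c1ncn2[C@@H]1O[C@H](CO)[C@@H](O)[C@H]1O`, has not yet been measured in this assay. It differs from compound 1 in one place: 2-cyanophenyl in place of 3-chlorophenyl on a saturated chain carbon bound to a sulfur. Both steps that bear on it, an 8.3-fold higher number from compound 1 to compound 2 (0.92 log units; beyond the scatter) and a 1.1-fold higher number from compound 1 to compound 3 (0.03 log units; within the scatter), are changes of the group on the phenyl ring attached to the saturated chain carbon bound to sulfur, and they pull in opposite directions. The nitrile is a group not yet tried in this series, so a modest rise in the number is the most defensible expectation, with a wide range. Compound 4 is therefore estimated at 60 nM, between 15 nM and 250 nM, an expected step of a 3.3-fold higher number from compound 1 to compound 4 (0.52 log units; beyond the scatter).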

Compound 4, inhibition constant: 38.9 nM
Beside the measured number, compound 4's estimate is 1.5-fold (0.19 log units) above it; measured number inside the range.
By their numbers in this assay, from the lowest: compounds 1, 3 and 4 (each within the scatter of the next, the first and the last beyond it); then compound 2.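

In this assay, the nitrile of 2-cyanophenyl, which brings a triple bond and a hydrogen-bond acceptor that 3-chlorophenyl lacks, is accepted on the saturated chain carbon bound to a sulfur at only a modest cost, a 2.1-fold higher number from compound 1 to compound 4 (0.33 log units; beyond the scatter), so this place is not limited to halogen-bearing phenyl groups. Among the groups with a substituent on the same ring carbon, cyano in place of iodo gives a 2.0-fold higher number from compound 3 to compound 4 (0.30 log units; within the scatter), while cyano in place of bromo gives a 3.9-fold lower number from compound 2 to compound 4 (0.59 log units; beyond the scatter), which leaves compound 2 as the one that stands apart rather than compound 4. Nothing available explains why the bromo compound differs from the iodo and cyano compounds.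

The compounds shown leave open how much of the spread comes from the group and how much from where it sits on the ring, as no group here appears at both ring places, so a pair such as 2-chlorophenyl and 3-cyanophenyl would be needed to separate the two. Also open, on these data alone, is whether this place accepts a phenyl ring carrying an amine or a carboxylic acid as readily as one carrying a nitrile.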